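A few compounds are considered here, and "the series" means these few. Any claim that something is new, unique, unknown or untested is made for them only; others in the source may bear on it.

Compound 1 `CC(=O)N1c2ccccc2CCC1C(=O)Nc1cc(C(F)(F)F)cc(C(F)(F)F)c1` and compound 2 `O=C(Nc1ccccc1C(F)(F)F)C1CCc2ccccc2N1C(=O)c1ccc(Cl)cc1` share the same core and were both tested in a functional assay on MDA-MB-231 cells (Homo sapiens) for cytotoxicity, read by sulforhodamine B assay, with a stated time of 72 h; a higher number here means a weaker inhibitor of growth, a lower number a stronger inhibitor of growth. In this assay compound 2 gives 533 nM. For compound 1 this assay reports only a limit, > 70000 nM, so its true number is not known; compound 1 stands at the limit of > 70000 nM in this assay, at which 1 of the 2 values shown sits. Compound 3 `O=C(Nc1cc(C(F)(F)F)cc(C(F)(F)F)c1)C1CCc2ccccc2N1` differs from compound 1 in one place: hydrogen in place of acetyl on a nitrogen on an aromatic ring in a ring. Among the measured compounds shown here, no measured pair shows this change, so there is nothing to read the step from. Compound 3 is expected to remain weak, with a step of an at least 1.1-fold lower number from compound 1 to compound 3 (0.06 log units; that floor lies within the scatter) expected to be no larger than the usual scatter. The estimate for compound 3 is 60000 nM, ranging from 15000 nM to 200000 nM.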

Compound 3, concentration for 50% growth inhibition: 8270 nM
Estimate against measurement, compound 3: 7.3-fold (0.86 log units) above; measured number below the stated range.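

Swapping the acetyl on this ring nitrogen for hydrogen is not a silent change in this assay: it gives an at least 8.4-fold lower number from compound 1 to compound 3 (0.92 log units; beyond the scatter). The group on this nitrogen therefore matters for growth inhibition, and the bare nitrogen of compound 3 is the better of these two options. The step is only a floor, since compound 1 carries a limit: the limit of > 70000 nM in this assay, at which 1 of the 3 values shown sits.

As far as these compounds go, whether a methyl or a longer chain on this nitrogen would behave more like acetyl or more like hydrogen remains open. This step also rests on a single pair.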